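An Isopropyl Group Joins the Core of Compound 3

This account rests on a few compounds, and the source may have more. Where it says the series, first, only, none or still open, it means among the compounds named here.

Of the compounds shown here, three sharing one fused core have been tested so far in a functional assay on the whole organism with Rattus norvegicus as the target, at a dose of 40 mg/kg by the intraperitoneal route; a lower number here means less inhibition, a higher number more inhibition at the dose given (going by the name of the read-out). Compound 1 `Cc1nc2c(OCc3ccccc3)ccc(C)n2c1C` gives 26% in this assay. Compound 2 `Cc1cc(OCc2ccccc2)c2nc(C)c(C)n2c1` gives 86% in this assay. Compound 3 `Nc1cnc2c(OCc3ccccc3)cccn12` gives 32% in this assay, the second highest of the three numbers; its nearest neighbour is compound 1, whose value lies within the usual scatter of that of compound 3, so the two cannot be told apart, while compound 2 stands far higher, beyond the scatter.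

Compound 4 `CC(C)c1nc2c(OCc3ccccc3)cccn2c1N` has not yet been measured. It differs from compound 3 in a single place: isopropyl in place of hydrogen on an aromatic carbon. Among the measured compounds shown here, no pair of measured compounds differs in only one spot, so there is no measured step of this kind to lean on; the wide gap between compound 1 and compound 2 shows only that compounds on this core can give very different numbers. For compound 4 the step of a number 8 percentage points higher from compound 3 to compound 4 (within the scatter) is expected to be modest and upward, and it may not exceed the scatter. Compound 4 is therefore estimated to give 40% in this assay, with a plausible range from 15% to 70%.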

Compound 4, a percentage reported as inhibition, in the whole organism at one dose (the size of the read-out at that dose, not a potency): 0%
Compound 4: the middle estimate sits 40 percentage points above what was measured; the whole stated range lies above it.
By their numbers in this assay, from the lowest: compound 4; then compounds 1 and 3 (each within the scatter of the next); then compound 2.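

Among the compounds shown here, compound 3 and compound 4 form the first measured pair on the shared core that differs in one place only, and the step is large: in this assay, isopropyl in place of hydrogen on an aromatic carbon gives a number 32 percentage points lower from compound 3 to compound 4 (beyond the scatter). This places a clear sensitivity at this carbon of the five-membered aromatic ring, next to the ring atom that bears an amino group, and compound 4 gives 0% at the single dose used, which describes the size of the read-out at that dose and not a potency. Nothing measured here offers an explanation for the fall.

The compounds shown leave open whether ethyl, a longer chain or a carboxylic acid on this same carbon would bring a step of similar size, or a much smaller one. They also leave open whether isopropyl at this place would have the same effect on a version of the core that carries no amino group on the neighbouring ring atom.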